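Closing an Open-Chain Amine into a Ring

The source may report more compounds than this note shows. Statements on the series, on what has been measured and on what is new or still open speak of the compounds shown alone.

The three measured compounds are:
Compound 1, `CC(C)N(C)c1ccc2cc(NC(=O)CCc3ccc(C(F)(F)F)cc3)ccc2n1`: 2 nM
Compound 2, `CN(c1ccc2cc(NC(=O)CCc3ccc(C(F)(F)F)cc3)ccc2n1)C1CCCC1`: 2 nM
Compound 3, `O=C(CCc1ccc(C(F)(F)F)cc1)Nc1ccc2nc(N3CC4CCC3CC4)ccc2c1`: 3 nM

All were tested in an assay on isolated protein for displacement of a labelled ligand from melanin-concentrating hormone receptor 1 (Homo sapiens); on this read-out higher numbers stand for weaker inhibition and lower numbers for stronger inhibition. Among the compounds with values here, compound 1 stands level with compound 2, and the two share the lowest number of the three; the only other comparison is a 1.5-fold higher number from compound 1 to compound 3 (0.18 log units; within the scatter), so compound 1 sits at the low end of a set whose numbers all lie close together.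

Compound 4, `O=C(CCc1ccc(C(F)(F)F)cc1)Nc1ccc2nc(N3CCCCC3)ccc2c1`, has not yet been measured. It differs from compound 1 in one place: piperidin-1-yl in place of isopropyl(methyl)amino on an aromatic carbon.

Within the data shown here, three measured steps bear on this change. Replacing one open-chain group on the same nitrogen with a ring gave no change at the digits printed from compound 1 to compound 2 (within the scatter), swapping the whole open-chain amine for a bridged bicyclic amine gave a 1.5-fold higher number from compound 1 to compound 3 (0.18 log units; within the scatter), and a 1.5-fold higher number from compound 2 to compound 3 (0.18 log units; within the scatter). Each of these changes at the same position left the number essentially where it was. A piperidin-1-yl group in this position is therefore expected to behave alike, and a 1.3-fold higher number from compound 1 to compound 4 (0.10 log units; within the scatter) is the estimated step. Compound 4 is expected to give about 2.5 nM, estimated between 1.2 nM and 6 nM.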

Compound 4, half-maximal inhibitory concentration: 12 nM
The estimate for compound 4 lay 4.8-fold (0.68 log units) below the measured number; measured number above the stated range.
By their numbers in this assay, from the lowest: compounds 1, 2 and 3 (each within the scatter of the next); then compound 4.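

At this position, not every amine is interchangeable. In this assay, within the data shown here, piperidin-1-yl gives a 6.0-fold higher number from compound 1 to compound 4 (0.78 log units; beyond the scatter) and a 6.0-fold higher number from compound 2 to compound 4 (0.78 log units; beyond the scatter), the first steps in this set to lie beyond the scatter. Having the amine nitrogen in a ring does not by itself separate the compounds: compound 3 also carries its nitrogen in a ring and stays within the scatter of compound 1, yet the simpler ring gives a 4.0-fold higher number from compound 3 to compound 4 (0.60 log units; beyond the scatter), so the shape of the ring system matters here, and nothing measured here explains the difference.

Still open, as far as these compounds go, is whether a pyrrolidin-1-yl ring, a morpholin-4-yl ring or a plain dimethylamino group would give numbers level with compounds 1, 2 and 3 or closer to compound 4.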